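Working notes: compound 1 to compound 4

A few compounds are considered here, and "the series" means these few. Any claim that something is new, unique, unknown or untested is made for them only; others in the source may bear on it.

Measured in a physicochemical assay for solubility, using the shake flask method, measured as kinetic solubility, with a stated time of 2 h, at pH 7.4; a lower number here means a less soluble compound, a higher number a more soluble compound
- compound 1 (`CN(Cc1ccc(Cl)cc1)c1cc(C(=O)Nc2ccccc2)ncn1`) gives < 5000 nM (a limit)
- compound 2 (`CN(Cc1ccc(C(F)(F)F)cc1)c1cc(C(=O)Nc2ccccc2)ncn1`) gives < 5000 nM (a limit)
- compound 3 (`CN(Cc1ccc(S(C)(=O)=O)cc1)c1cc(C(=O)Nc2ccccc2)ncn1`) gives 10000 nM

Compound 1 holds only a limit (< 5000 nM). Compound 4 (`CN(Cc1ccc(Cl)cc1)c1cc(C(=O)Nc2ccncc2)ncn1`) keeps the core of compound 1 and differs in one place (pyridin-4-yl in place of phenyl on an amide-type nitrogen): pyridin-4-yl in place of phenyl on an amide-type nitrogen.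

For the measured compounds named here, no measured step touches that place. The measured steps exchange groups on an aromatic carbon (a step that the two limits leave unreadable from compound 1 to compound 2; an at least 2.0-fold higher number from compound 2 to compound 3 (0.30 log units; that floor lies within the scatter)). Only a weak upward lean can be borrowed, from compound 3 and its step (an at least 2.0-fold higher number from compound 1 to compound 3 (0.30 log units; that floor lies within the scatter)).

In this assay a small upward step is therefore expected (an at least 1.2-fold higher number from compound 1 to compound 4 (0.07 log units; that floor lies within the scatter)), and it may not leave the scatter. For compound 4 the estimated value is 6000 nM, with an expected range from 2000 nM to 20000 nM.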

Compound 4, solubility: < 5000 nM
Compound 4: only a limit was reported; the forecaster's own chance of this, stated with the estimate: 45%; at least 1.2-fold (0.07 log units) between middle value and limit.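

Compound 1 and compound 4 both hold only a limit, so no step can be read between them: the limit of < 5000 nM in this assay, at which 3 of the 4 values shown sit.

Going by these compounds, whether pyridin-4-yl in place of phenyl on an amide-type nitrogen changes the solubility read-out, and in which direction, stays open.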